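This account rests on a few compounds, and the source may have more. Where it says the series, first, only, none or still open, it means among the compounds named here.

Compound 1 `Cc1ccc(C(=O)Nc2ccc(CNC(=O)OCc3cccnc3)cc2)c(N2CCCC2)c1` in a toxicity assay on GES1 cells (Homo sapiens) for inhibition, read by MTT assay, with a stated time of 72 h; a higher number here means a weaker inhibitor, a lower number a stronger inhibitor: compound 1 gives > 100000 nM, which is a limit of the assay, not a number.
Compound 2 `O=C(NCc1ccc(NC(=O)c2cc(Cl)ccc2N2CCCC2)cc1)OCc1cccnc1`: in this assay compound 2 gives > 100000 nM, again a limit of the assay.
Compound 3 `Cc1ccc(N2CCCC2)c(C(=O)Nc2ccc(CNC(=O)OCc3cccnc3)cc2)c1`: in this assay compound 3 gives > 100000 nM, also a limit.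

Among the compounds with values here, compound 2 therefore stands only at a limit in this assay; every value shown sits there (the limit of > 100000 nM in this assay, at which 3 of the 3 values shown sit), so no compound can be ranked against another. Within the data shown here, the one measured step that bears on the change, a step that the two limits leave unreadable from compound 2 to compound 3, cannot be read, since both ends are limits. Compound 4 `COc1ccc(N2CCCC2)c(C(=O)Nc2ccc(CNC(=O)OCc3cccnc3)cc2)c1` differs from compound 2 by methoxy in place of chloro on an aromatic carbon. With nothing but limits to go on, compound 4 is expected to follow, with a step estimated at a step that the limit leaves unreadable from compound 2 to compound 4. Compound 4 is thus estimated at 150000 nM, within 50000 nM to 500000 nM.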

Compound 4, half-maximal inhibitory concentration: > 100000 nM
Compound 4: no number, only a limit; the forecaster's own chance of this, stated with the estimate: 85%; the middle value does not contradict the limit.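

No new step can be read from compound 4 to compound 2 or compound 3, since each comparison has a limit at both ends: the limit of > 100000 nM in this assay, at which 4 of the 4 values shown sit.

The compounds shown leave open how chloro, methyl and methoxy truly compare in this assay.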